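Aryl swap on the amine of a tricyclic quinone core

The compounds below may be only part of what the source reports. "The series", "measured", "known", "first", "only" and "open" are said of these compounds alone.

Measured compounds in a functional assay on HeLa cells (Homo sapiens) for inhibition, read by sulforhodamine B assay; on this read-out lower numbers stand for stronger inhibition and higher numbers for weaker inhibition:
compound 1, `O=C1C(Nc2cccc(Cl)c2)=CC(=O)c2c1nc1n2[C@H]2OC[C@@H](O)[C@H]2OC1`: 7970 nM
compound 2, `Cc1ccc(NC2=CC(=O)c3c(nc4n3[C@H]3OC[C@@H](O)[C@H]3OC4)C2=O)cc1C`: 4320 nM
compound 3, `O=C1C=C(NCc2ccccc2)C(=O)c2c1nc1n2[C@H]2OC[C@@H](O)[C@H]2OC1`: a limit, > 8000 nM

Of the two numbers given, compound 1 has the higher one; its nearest neighbour is compound 2, and the step of a 1.8-fold lower number from compound 1 to compound 2 (0.27 log units; within the scatter) stays within the scatter. The value of compound 3 is a limit of this assay the limit of > 8000 nM in this assay, at which 1 of the 3 values shown sits, and gives no number.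

Compound 4, `Cc1ccc(NC2=CC(=O)c3c(nc4n3[C@H]3OC[C@@H](O)[C@H]3OC4)C2=O)cc1`, differs from compound 1 by 4-methylphenyl in place of 3-chlorophenyl on an amine nitrogen. For the measured compounds named here, the only measured step that bears on it is a 1.8-fold lower number from compound 1 to compound 2 (0.27 log units; within the scatter), which exchanges the same 3-chlorophenyl for a differently methylated phenyl and stays within the scatter. Compound 4 is therefore expected to sit close to compound 1, with a step of a 1.4-fold lower number from compound 1 to compound 4 (0.16 log units; within the scatter) that carries no clear direction beyond the scatter. The estimate for compound 4 is 5500 nM, with a range from 2500 nM to 12000 nM.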

Compound 4, half-maximal inhibitory concentration: 6590 nM
For compound 4 the middle estimate is 1.2-fold (0.08 log units) below the measured one, within the range that was stated.
By their numbers in this assay, from the lowest: compounds 2, 4 and 1 (each within the scatter of the next). At a limit, above all of these: compound 3.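

Putting 4-methylphenyl in place of 3-chlorophenyl on the amine nitrogen gives a 1.2-fold lower number from compound 1 to compound 4 (0.08 log units; within the scatter) in this assay while hydrogen in place of methyl on an aromatic carbon gives a 1.5-fold higher number from compound 2 to compound 4 (0.18 log units; within the scatter) and so both new steps stay within the scatter. Compounds 1, 2 and 4 therefore cannot be told apart on this read-out, whether the phenyl carries chlorine, one methyl or two methyls. As far as these compounds go, whether an amine or a carboxylic acid on this phenyl would move the number beyond the scatter stays open. Nothing measured here bears on what lies behind these close values.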